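Trading the benzyl arm for a chloropropyl chain

The compounds below may be only part of what the source reports. "The series", "measured", "known", "first", "only" and "open" are said of these compounds alone.

In a functional assay on HeLa cells (Homo sapiens) for antiproliferative activity, read by MTT assay, with a stated time of 72 h (a lower number here means a stronger inhibitor, a higher number a weaker inhibitor), the measured compounds gave these numbers:
compound 1 `O=c1[nH]c(=O)n(CCC(CO)CO)cc1-c1cccs1`: 7800 nM
compound 2 `CC(=O)OCC(CCn1cc(C#Cc2ccc(Br)cc2)c(=O)n(C(=O)c2ccccc2)c1=O)COC(C)=O`: 47200 nM
compound 3 `CC(=O)OCC(CCn1cc(C#CCc2ccccc2)c(=O)n(C(=O)c2ccccc2)c1=O)COC(C)=O`: 29900 nM

Compound 3 holds the second highest of the three numbers. Its nearest neighbour is compound 2, and the step of a 1.6-fold lower number from compound 2 to compound 3 (0.20 log units; within the scatter) stays within the scatter; compound 1 lies lower, beyond the scatter. Compound 4 `CC(=O)OCC(CCn1cc(C#CCCCCl)c(=O)n(C(=O)c2ccccc2)c1=O)COC(C)=O` differs from compound 3 by 2-chloroethyl in place of phenyl on a saturated chain carbon bound to a triple-bonded carbon. Among the compounds with values here, the only measured step, a 1.6-fold lower number from compound 2 to compound 3 (0.20 log units; within the scatter), concerns the group on the triple-bonded carbon and was within the scatter; no measured step exchanges an aromatic ring for an open chain. A step no larger than the scatter is therefore expected, a 1.0-fold higher number from compound 3 to compound 4 (0.00 log units; within the scatter). Compound 4 is estimated at 30000 nM, with a range from 10000 nM to 90000 nM.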

Compound 4, half-maximal inhibitory concentration: 52800 nM
Compound 4: middle estimate off by 1.8-fold (0.25 log units), on the low side; low and high end bracket the measured number.
By their numbers in this assay, from the lowest: compound 1; then compounds 3, 2 and 4 (each within the scatter of the next).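

In this assay, swapping an aromatic arm on the triple-bonded carbon for the open 3-chloropropyl chain gives no step beyond the scatter: replacing benzyl gives a 1.8-fold higher number from compound 3 to compound 4 (0.25 log units; within the scatter), and replacing 4-bromophenyl gives a 1.1-fold higher number from compound 2 to compound 4 (0.05 log units; within the scatter). At this position, then, the three groups shown, two with an aromatic ring and one with no ring, cannot be told apart, so a ring is not needed to stay in this range. Nothing available explains this result. On these data alone, whether an amine in place of the chlorine, or a longer chain, would move the number beyond the scatter remains open.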